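Hydroxyphenyl ether on the acid core

A few compounds are considered here, and "the series" means these few. Any claim that something is new, unique, unknown or untested is made for them only; others in the source may bear on it.

Compound 1 `COC(=O)c1c(F)cccc1-c1ccc(CCc2ncc(CC(C)(C)C)n2CCO)cc1` is the methyl ester of the pair. In an assay on cells for agonist activity at Bombesin receptor subtype-3 (Mus musculus), read by HTRF and inositol phosphate accumulation, with a stated time of 1 h (a lower number here means that less compound is needed, a higher number that more compound is needed for the effect), compound 1 gives 24 nM. Compound 2 `COC(=O)c1c(F)cccc1-c1ccc(CCc2ncc(CC(C)(C)C)n2CCOc2cccc(O)c2)cc1` carries the change 3-hydroxyphenyl in place of hydrogen on an oxygen on a saturated carbon and in this assay compound 2 gives 25 nM, the step being a 1.0-fold higher number from compound 1 to compound 2 (0.02 log units; within the scatter). Compound 3 `CC(C)(C)Cc1cnc(CCc2ccc(-c3cccc(F)c3C(=O)O)cc2)n1CCO` differs from compound 1 by hydrogen in place of methyl on an oxygen next to a carbonyl group; in this assay compound 3 gives 2 nM, a step of a 12-fold lower number from compound 1 to compound 3 (1.08 log units; beyond the scatter), and compound 3 holds the lowest number of the three measured compounds, both other steps lying beyond the scatter.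

Compound 4 `CC(C)(C)Cc1cnc(CCc2ccc(-c3cccc(F)c3C(=O)O)cc2)n1CCOc1cccc(O)c1` has not been measured. It differs from compound 3 by 3-hydroxyphenyl in place of hydrogen on an oxygen on a saturated carbon, the same change that leads from compound 1 to compound 2, at the same place on both cores; the two cores themselves differ by hydrogen in place of methyl on an oxygen next to a carbonyl group. Among the measured compounds shown here, only one earlier example of the change exists, so the expectation rests on it alone. The step from compound 3 to compound 4 is expected to be a 1.1-fold higher number from compound 3 to compound 4 (0.04 log units; within the scatter) because a 1.0-fold higher number from compound 1 to compound 2 (0.02 log units; within the scatter) stayed within the scatter. Compound 4 is therefore estimated at 2.2 nM in this assay, with a likely range from 0.9 nM to 5.5 nM.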

Compound 4, half-maximal effective concentration: 0.8 nM
Estimate against measurement, compound 4: 2.8-fold (0.44 log units) above; the measured number lies below the stated range.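

In this assay, 3-hydroxyphenyl in place of hydrogen on the acid core gives a 2.5-fold lower number from compound 3 to compound 4 (0.40 log units; beyond the scatter), and hydrogen in place of methyl on the core bearing the ether gives a 31-fold lower number from compound 2 to compound 4 (1.49 log units; beyond the scatter). Among the compounds shown here, the 3-hydroxyphenyl change therefore cannot be said to behave differently on the ester and acid cores, even though only the step on the acid core lies beyond the scatter: the same change on two cores in this assay, a 1.0-fold higher number (0.02 log units; within the scatter) from compound 1 to compound 2 and a 2.5-fold lower number (0.40 log units; beyond the scatter) from compound 3 to compound 4, 2.6-fold (0.42 log units) apart, within the scatter of two such steps. The change from methyl ester to carboxylic acid is large on both cores, but a single pair for each change does not show that either result extends to another core or gives a size that can be relied on: the same change on two cores in this assay, a 12-fold lower number (1.08 log units; beyond the scatter) from compound 1 to compound 3 and a 31-fold lower number (1.49 log units; beyond the scatter) from compound 2 to compound 4, 2.6-fold (0.42 log units) apart, within the scatter of two such steps.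

As far as these compounds go, it remains open whether an unsubstituted phenyl, or an amine in place of the hydroxy group on the phenyl, would give a similar step. A longer chain in place of the 2-(3-hydroxyphenoxy)ethyl group is equally untested by the compounds shown.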